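The source may report more compounds than this note shows. Statements on the series, on what has been measured and on what is new or still open speak of the compounds shown alone.

Measured compounds in a functional assay on the whole organism for inhibition, with Rattus norvegicus as the target, read by paw edema, with stated times of 1 h and 3 h, at a dose of 50 mg/kg by the oral route; a higher number here means more inhibition at the dose given (going by the name of the read-out), a lower number less inhibition:

compound 1, `C/C(=N\OCC(=O)O)c1ccccc1Cl` — this assay: < 20%
compound 2, `C/C(=N\OCC(=O)O)c1ccc(C)cc1` — this assay: 20%
compound 3, `COc1ccc(/C(C)=N/OCC(=O)O)cc1` — this assay: < 20%

The value of compound 1 in this assay is a limit of the assay, not a number. The value of compound 3 in this assay is likewise a limit. Compound 2 therefore holds the only number shown in this assay; the two other values are limits, so its standing relative to them cannot be ordered.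

Going by the values given here, one measured step bears on the aromatic substituent: a number no higher from compound 2 to compound 3 (the limit leaves the size open). Its size is not readable, as the result is held at the limit of < 20% in this assay, at which 2 of the 3 values shown sit.

The step to be followed goes from compound 2 to compound 4, `CSc1ccc(/C(C)=N/OCC(=O)O)cc1`, which has not been measured in this assay. The change is methylsulfanyl in place of methyl on an aromatic carbon. Among the compounds with values here, no measured step shows a methylsanfanyl group; the nearest comparison is the methoxy step, whose size is open. No step beyond the scatter is therefore expected in this assay.

Compound 4 is estimated at 20%, with a range from 5% to 38%. The step this estimate implies is no change at the digits printed from compound 2 to compound 4 (within the scatter), and it is expected to lie within the scatter; the measurement follows.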

Compound 4, a percentage reported as inhibition, in the whole organism at one dose (the size of the read-out at that dose, not a potency): < 20%
Compound 4 gave a limit, no number; the forecaster's own chance of this, stated with the estimate: 40%; the middle value sits exactly at the limit.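

In this assay compound 4 gives < 20%, which is a limit of the assay and not a number. Methylsulfanyl in place of methyl gives a number no higher from compound 2 to compound 4 (the limit leaves the size open), and the methoxy replacement at the same place gives a number no higher from compound 2 to compound 3 (the limit leaves the size open), so two different replacements of the methyl group now point the same way without either giving a higher number. The size of these steps cannot be read, and compound 3 and compound 4 cannot be ordered against each other, because the results are held at: the limit of < 20% in this assay, at which 3 of the 4 values shown sit.

The only number in this set remains that of compound 2 at 20%, so no substituent at this position has yet been shown to raise the inhibition beyond the scatter. As far as these compounds go, whether an amine, a carboxylic acid or a longer chain on this aromatic carbon would give a readable number in this assay stays open.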